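Swapping the sulfonyl aryl group: a halogenated variant

The source may report more compounds than this note shows. Statements on the series, on what has been measured and on what is new or still open speak of the compounds shown alone.

Measured so far in an assay on isolated protein for displacement of a labelled ligand from metabotropic glutamate receptor 5 (Homo sapiens), with a stated time of 60 min, tested at 1 uM; on this read-out lower numbers stand for less inhibition and higher numbers for more inhibition at the one concentration tested (going by the name of the read-out):
compound 1, `COc1ccc(S(=O)(=O)c2cnc3ccc(C)cc3c2N2CCC(C)CC2)cc1`, gives 62%
compound 2, `Cc1ccc2ncc(S(=O)(=O)c3ccc(F)cc3)c(N3CCC(C)CC3)c2c1`, gives 90%
compound 3, `Cc1ccc2ncc(S(=O)(=O)c3ccc(C)c(C)c3)c(N3CCC(C)CC3)c2c1`, gives 90%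

Compound 3 shares a core with the other two and differs only in the group on the sulfonyl sulfur. Its number in this assay is level with that of compound 2, and together they sit at the top of the three; the step of a number 28 percentage points higher from compound 1 to compound 3 (beyond the scatter) is beyond the scatter, while no change at the digits printed from compound 2 to compound 3 (within the scatter) is within it.

Compound 4, `Cc1ccc2ncc(S(=O)(=O)c3ccc(F)c(Cl)c3)c(N3CCC(C)CC3)c2c1`, is the next variation at the same place:
3-chloro-4-fluorophenyl in place of 3,4-dimethylphenyl on a sulfonyl sulfur

Among the compounds with values here, two measured steps bear on this. Replacing a 4-methoxyphenyl by 3,4-dimethylphenyl gave a number 28 percentage points higher from compound 1 to compound 3 (beyond the scatter), a modest gain, whereas replacing a 4-fluorophenyl by 3,4-dimethylphenyl gave no change at the digits printed from compound 2 to compound 3 (within the scatter). A fluoro-bearing aryl group (compound 2) and a dimethyl-bearing one (compound 3) therefore read alike, and compound 4 carries halogens rather than a methoxy. The expected step is a number 2 percentage points lower from compound 3 to compound 4 (within the scatter), small and within the scatter. Compound 4 is thus estimated at 88%, with a range from 72% to 97%.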

Compound 4, a percentage reported as inhibition, at one concentration (the size of the read-out at that concentration, not a potency): 93%
The estimate for compound 4 lay 5 percentage points below the measured number; measured number inside the range.
By their numbers in this assay, from the lowest: compound 1; then compounds 2, 3 and 4 (each within the scatter of the next).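

In this assay, 3-chloro-4-fluorophenyl in place of 3,4-dimethylphenyl on the sulfonyl sulfur gives (a number 3 percentage points higher from compound 3 to compound 4 (within the scatter)), and chloro in place of hydrogen on an aromatic carbon gives (a number 3 percentage points higher from compound 2 to compound 4 (within the scatter)), so this position accepts a group carrying both chloro and fluoro without a change beyond the scatter. The new group also reads well clear of the 4-methoxyphenyl group (a number 31 percentage points higher from compound 1 to compound 4 (beyond the scatter)), leaving compound 1 apart from the other three. Nothing available explains these results.

Going by these compounds, how an aryl group carrying an amine or a carboxylic acid, or a longer alkyl chain in place of the aryl group, would read on the sulfonyl sulfur remains open. Any order of stronger or weaker effect among compound 2, compound 3 and compound 4 at the one concentration tested also remains open.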